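This account rests on a few compounds, and the source may have more. Where it says the series, first, only, none or still open, it means among the compounds named here.

Compound 1 `CCCCC/C=C\C/C=C\C/C=C\C=C\C(CCCS)CCCC(=O)O` is the starting point. Among the measured compounds shown here, in an assay for inhibition of Polyunsaturated fatty acid 5-lipoxygenase (Rattus norvegicus) (on this read-out lower numbers stand for stronger inhibition and higher numbers for weaker inhibition), compound 1 gives 36000 nM, the lowest of the two numbers measured so far. Compound 2 `CCCCC/C=C\C/C=C\C/C=C\C=C\C(CCCC(=O)O)CC(=O)O` gives 96000 nM in this assay, and the step of a 2.7-fold higher number from compound 1 to compound 2 (0.43 log units; beyond the scatter) came with a carboxy in place of 2-sulfanylethyl on a saturated chain carbon, two bonds along the chain from a double-bonded chain carbon. The unmeasured compound 3 `CCCCC/C=C\C/C=C\C/C=C\C=C\C(N)CCCC(=O)O` differs from compound 1 by amino in place of 3-sulfanylpropyl on a saturated chain carbon bound to a double-bonded chain carbon and a saturated chain carbon. For the measured compounds named here, the single measured step bears on this change only loosely: in both, a sulfanyl-bearing group of compound 1 gives way to a far smaller group, and in the measured case the number rose modestly. A shift of similar kind is therefore expected here, with the estimate meaning a 2.5-fold higher number from compound 1 to compound 3 (0.40 log units; beyond the scatter). For compound 3 the estimate is 90000 nM, within a range from 30000 nM to 300000 nM.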

Compound 3, half-maximal inhibitory concentration: 25000 nM
Compound 3: middle estimate off by 3.6-fold (0.56 log units), on the high side; the measured number lies below the stated range.
By their numbers in this assay, from the lowest: compounds 3 and 1 (each within the scatter of the next); then compound 2.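

On this saturated chain carbon, 3-sulfanylpropyl, with its 4 heavy atoms, gives way to amino, with 1, and in this assay the result is a 1.4-fold lower number from compound 1 to compound 3 (0.16 log units; within the scatter). The earlier compounds shown here did not show that this group can be exchanged for one so much smaller with no change beyond the scatter. Amino in place of carboxymethyl at the same carbon does register, with a 3.8-fold lower number from compound 2 to compound 3 (0.58 log units; beyond the scatter), so the identity of the group here can matter, but nothing measured explains why the numbers fall as they do.

As far as these compounds go, whether a hydroxy group or a methylamino group on this carbon would give a similar number stays open. So does the result for a plain hydrogen there, or for a sulfanylmethyl group, which would show how much of the chain matters.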